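Swapping the aryl group on a weakly cytotoxic scaffold

This account rests on a few compounds, and the source may have more. Where it says the series, first, only, none or still open, it means among the compounds named here.

Two measured compounds share an amide-linked core and differ in their peripheral groups. Compound 1 `Cc1cc(=O)n(-c2cccc(F)c2)nc1C(=O)Nc1ccc(Oc2ncnc3[nH]ccc23)cc1` carries a 3-fluorophenyl group on the ring nitrogen. In a functional assay on A549 cells (Homo sapiens) for cytotoxicity, read by MTT assay, with a stated time of 72 h (on this read-out lower numbers stand for stronger inhibition and higher numbers for weaker inhibition), compound 1 gives 34800 nM. Compound 2 `Cc1cc(=O)n(-c2ccc(Br)cc2F)nc1C(=O)Nc1ccc(Oc2ncnc3c2ccn3C)cc1` differs from compound 1 in two places at once, so no single change can be isolated between them. In this assay compound 2 gives 47300 nM. Compound 2 has the highest of the two numbers, but its nearest neighbour, compound 1, lies within the scatter, so the two values show no separation.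

Compound 3 `Cc1cc(=O)n(-c2cccc(F)c2)nc1C(=O)Nc1ccc(Oc2ncnc3c2ccn3C)cc1` is a hybrid: it keeps the core of compound 2 and takes the aryl group of compound 1. The change is 3-fluorophenyl in place of 4-bromo-2-fluorophenyl on an aromatic nitrogen. Since compound 1 and compound 2 already sit within the scatter of each other despite differing in both the aryl group and the core, the expected step is a 1.2-fold lower number from compound 2 to compound 3 (0.07 log units; within the scatter), none beyond the scatter. Compound 3 is accordingly estimated at 40000 nM, with a range from 15000 nM to 100000 nM.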

Compound 3, half-maximal inhibitory concentration: 23400 nM
Compound 3: middle estimate off by 1.7-fold (0.23 log units), on the high side, within the range that was stated.
By their numbers in this assay, from the lowest: compounds 3, 1 and 2 (each within the scatter of the next, the first and the last beyond it).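

On the core of compound 2, which carries a methyl on its aromatic nitrogen, 3-fluorophenyl in place of 4-bromo-2-fluorophenyl on the aromatic nitrogen next to the ring nitrogen gives a 2.0-fold lower number from compound 2 to compound 3 (0.31 log units; beyond the scatter) in this assay. Going by these compounds alone, this is the first change at this position that can be read on its own, and it only just clears the scatter, whereas the other single change, methyl in place of hydrogen on an aromatic nitrogen with the 3-fluorophenyl group held constant, gives a 1.5-fold lower number from compound 1 to compound 3 (0.17 log units; within the scatter) and shows no separation. Nothing available explains why the aryl swap moves the number.

The swap removes the bromine and relocates the fluorine together, so the compounds shown cannot say which of these two differences carries the step, or whether the methyl change would read the same with 4-bromo-2-fluorophenyl in place. On these data alone, it also remains open how this read-out would respond to a group of another kind at this nitrogen, such as a simple alkyl chain, or to an amine or a carboxylic acid on the aryl ring.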